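Thiosemicarbazide series: pyrrolidinyl variant at the thiocarbonyl carbon

The source may report more compounds than this note shows. Statements on the series, on what has been measured and on what is new or still open speak of the compounds shown alone.

Compound 2 `N/C(=N\NC(=S)N1CCCCC1)c1ccccn1` stands highest of the two measured in a functional assay on A-375 cells (Homo sapiens) for cytotoxicity, read by MTT assay, with a stated time of 72 h, tested at 30 uM (on this read-out higher numbers stand for more inhibition of growth at the one concentration tested and lower numbers for less inhibition of growth), where compound 2 gives 87%. Compound 1 `N/C(=N\NC(=S)N1CCOCC1)c1ccccn1` gives 15% in this assay; the step of a number 72 percentage points higher from compound 1 to compound 2 (beyond the scatter) is the only one recorded. Compound 3 `N/C(=N\NC(=S)N1CCCC1)c1ccccn1` differs from compound 2 by pyrrolidin-1-yl in place of piperidin-1-yl on a thiocarbonyl carbon. For the measured compounds named here, no measured step alters ring size at this position; the one step available shows only that this assay responds strongly to the group on the thiocarbonyl carbon. For compound 3 the expected step is a number 17 percentage points lower from compound 2 to compound 3 (beyond the scatter). The estimate for compound 3 is 70%, range 35% to 95%.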

Compound 3, percent growth inhibition at one concentration: 86%
Compound 3: middle estimate off by 16 percentage points, on the low side, and the stated range covers the measured number.
By their numbers in this assay, from the lowest: compound 1; then compounds 3 and 2 (each within the scatter of the next).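

Pyrrolidin-1-yl in place of piperidin-1-yl gives a number 1 percentage points lower from compound 2 to compound 3 (within the scatter) in this assay, so this read-out does not separate the two rings on the thiocarbonyl carbon. Pyrrolidin-1-yl in place of morpholin-4-yl gives a number 71 percentage points higher from compound 1 to compound 3 (beyond the scatter), so the large step seen earlier is not specific to piperidin-1-yl, and among these three compounds only compound 1 stands apart. No measured evidence bears on the reason for this difference.

As far as these compounds go, whether azepan-1-yl or an open-chain dimethylamino group on the thiocarbonyl carbon matches compound 2 and compound 3 remains open. So does whether piperazin-1-yl falls with morpholin-4-yl or with the two rings that carry only carbon and the one nitrogen.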